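Trading (trifluoromethyl)carbonyl for 2,2,2-trifluoroethyl

The source may report more compounds than this note shows. Statements on the series, on what has been measured and on what is new or still open speak of the compounds shown alone.

Compound 1 `N#CCC(c1ccccc1)c1c(-c2ccccc2)[nH]c2cc(Cl)ccc12`: 0.375 h
Compound 2 `O=C(C(c1ccccc1)c1c(-c2ccccc2)[nH]c2ccccc12)C(F)(F)F`: 0.69 h
Compound 3 `Cc1ccc2c(C(C(=O)C(F)(F)F)c3ccccc3)c(-c3ccccc3)[nH]c2c1`: 0.413 h

These half-lives come from an ADME assay on microsomes from liver (Rattus norvegicus) for metabolic stability, read by LC-MS, using NADPH, tested at 3 uM; a lower number here means that the compound disappears faster, a higher number that the compound lasts longer. Compound 3, at 0.413 h, lies within the scatter of both compound 1 and compound 2. The unmeasured compound 4 `Cc1ccc2c(C(CC(F)(F)F)c3ccccc3)c(-c3ccccc3)[nH]c2c1` differs from it in one place: 2,2,2-trifluoroethyl in place of (trifluoromethyl)carbonyl on a saturated chain carbon bound to two aromatic carbons. Going by the values given here, the only measured step, a 1.7-fold lower number from compound 2 to compound 3 (0.22 log units; within the scatter), is methyl in place of hydrogen on an aromatic carbon. Among the compounds with values here, that is a different change, so it offers little guidance, and no measured pair shows this swap directly. Compound 1, which has a nitrile and no carbonyl but also differs elsewhere, gives 0.375 h, within the scatter of compound 3. No step beyond the scatter is therefore expected in this assay. The expected change is a 1.0-fold lower number from compound 3 to compound 4 (0.01 log units; within the scatter). For compound 4 the estimated half-life is 0.4 h, with an expected range of 0.15 h to 1 h.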

Compound 4, half-life: 0.47 h
Estimate against measurement, compound 4: 1.2-fold (0.07 log units) below, and the stated range covers the measured number.
By their numbers in this assay, from the lowest: compounds 1, 3, 4 and 2 (each within the scatter of the next).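

In this assay, going by these compounds alone, the direct swap of (trifluoromethyl)carbonyl for 2,2,2-trifluoroethyl gives a 1.1-fold higher number from compound 3 to compound 4 (0.06 log units; within the scatter), the first reading of this change at this position. In this pair, then, the carbonyl can be removed with no step beyond the scatter in half-life. Nothing available explains why the half-life holds. As far as these compounds go, it remains open whether the same swap behaves alike on the core of compound 2, which lacks the methyl. Also open, from the compounds shown here alone, is what an amine or a carboxylic acid would give on this saturated chain carbon.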